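A few compounds are considered here, and "the series" means these few. Any claim that something is new, unique, unknown or untested is made for them only; others in the source may bear on it.

Three compounds have been measured in a functional assay on SW480 cells (Homo sapiens) for cytotoxicity, read by MTT assay, with a stated time of 48 h; a higher number here means a weaker inhibitor, a lower number a stronger inhibitor:

Compound 1 `Cc1ccc(Cn2cc(COc3ccc4c(=O)ccoc4c3)nn2)cc1` gives 10400 nM.
Compound 2 `N#Cc1ccc(Cn2cc(COc3ccc4c(=O)ccoc4c3)nn2)cc1` gives only a limit, > 100000 nM.
Compound 3 `O=c1ccoc2cc(OCc3cn(Cc4cccc(F)c4)nn3)ccc12` likewise gives only a limit, > 100000 nM.

Compound 2 therefore stands at the weak end of what this assay can read, and compound 3 shares that limit, so no number separates the two. The shared core carries a benzyl-type arm on the triazole, and the group on that phenyl ring is what varies. Swapping the methyl of compound 1 for a cyano gave an at least 9.6-fold higher number from compound 1 to compound 2 (0.98 log units; beyond the scatter), and swapping its whole 4-methylphenyl for 3-fluorophenyl gave an at least 9.6-fold higher number from compound 1 to compound 3 (0.98 log units; beyond the scatter); in both cases the number moved beyond the scatter towards weaker inhibition.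

Compound 4 `CC(C)(C)c1ccc(Cn2cc(COc3ccc4c(=O)ccoc4c3)nn2)cc1` is the next compound to be measured. It differs from compound 2 by tert-butyl in place of cyano on an aromatic carbon. This change brings back an alkyl group at the same position as the methyl of compound 1, so the relevant comparison is the step from compound 1 to compound 2, read in reverse. Compound 4 is expected to come back into the readable range, with an at least 6.6-fold lower number from compound 2 to compound 4 (0.82 log units; beyond the scatter) expected. For compound 4 an estimate of 15000 nM is made, in a range from 5000 nM to 60000 nM.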

Compound 4, half-maximal inhibitory concentration: 28800 nM
For compound 4 the middle estimate is 1.9-fold (0.28 log units) below the measured one, within the range that was stated.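

Going by these compounds alone, with tert-butyl at this position the number returns to the readable range, with an at least 3.4-fold lower number from compound 2 to compound 4 (0.54 log units; beyond the scatter), so methyl is not the only alkyl group that gives a readable value here. The value of compound 2 is a limit and not a number, so this step gives only a bound on the true size: the limit of > 100000 nM in this assay, at which 2 of the 4 values shown sit. Going from methyl to the larger tert-butyl still weakens the result, with a 2.8-fold higher number from compound 1 to compound 4 (0.44 log units; beyond the scatter), so the two alkyl groups are not interchangeable at this position.

The compounds shown leave open how the number moves across alkyl groups of intermediate size, such as ethyl or isopropyl. They also leave open whether a methoxy group or an amine at this position would give a readable value, as the alkyl groups do, or a limit, as cyano does.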